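The source may hold more compounds than are shown below. What is called first, only, known or untested is meant among the compounds shown, and "the series" means these compounds.

Measured compounds:
compound 1, `O=C(CN1CCN(c2cc3c(cc2F)c(=O)c(C(=O)O)cn3C2CC2)CC1)Nc1ccc(C(=O)/C=C/c2cccc(Cl)c2)cc1` — in a physicochemical assay for solubility, at pH 7.8 (a lower number here means a less soluble compound, a higher number a more soluble compound), compound 1 gives 29.7 ug/mL
compound 2, `COc1ccc(/C=C/C(=O)c2ccc(NC(=O)CN3CCN(c4cc5c(cc4F)c(=O)c(C(=O)O)cn5C4CC4)CC3)cc2)cc1OC` — in this assay compound 2 gives 0.68 ug/mL

Of these two, compound 2 stands lowest in this assay, and its nearest neighbour is compound 1, whose number is higher by the step of a 44-fold lower number from compound 1 to compound 2 (1.64 log units; beyond the scatter) read backwards. Within the data shown here, the single measured step, a 44-fold lower number from compound 1 to compound 2 (1.64 log units; beyond the scatter), came from putting 3,4-dimethoxyphenyl in place of 3-chlorophenyl on the chain carbon, and it was large and beyond the scatter.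

Compound 3, `O=C(CN1CCN(c2cc3c(cc2F)c(=O)c(C(=O)O)cn3C2CC2)CC1)Nc1ccc(C(=O)/C=C/c2cccc([N+](=O)[O-])c2)cc1`, has not yet been measured. The change from compound 2 is 3-nitrophenyl in place of 3,4-dimethoxyphenyl on a double-bonded chain carbon bound to a double-bonded chain carbon. Among the measured compounds shown here, this undoes the one measured step in part: the 3,4-dimethoxyphenyl that entered between compound 1 and compound 2 leaves again, and a 3-nitrophenyl comes in its place. For the measured compounds named here, no measured step says what 3-nitrophenyl does next to 3-chlorophenyl, so the direction rests only on the large drop from compound 1 to compound 2 being reversed. A sizeable rise beyond the scatter in this assay is expected, though not necessarily back to the level of compound 1. The expected step is a 12-fold higher number from compound 2 to compound 3 (1.07 log units; beyond the scatter). Compound 3 is therefore estimated at 8 ug/mL, with a range from 1.5 ug/mL to 40 ug/mL.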

Compound 3, solubility: 27.4 ug/mL
For compound 3 the middle estimate is 3.4-fold (0.53 log units) below the measured one, and the stated range covers the measured number.
By their numbers in this assay, from the lowest: compound 2; then compounds 3 and 1 (each within the scatter of the next).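

The solubility assay (this assay) now shows that the large fall seen with 3,4-dimethoxyphenyl on this double-bonded chain carbon is not a fixed feature of the shared core: with 3-nitrophenyl in its place, the number recovers (a 40-fold higher number from compound 2 to compound 3 (1.61 log units; beyond the scatter)). Putting nitro in place of chloro on an aromatic carbon makes no difference that can be told from the scatter (a 1.1-fold lower number from compound 1 to compound 3 (0.04 log units; within the scatter)), so among these three compounds 3-chlorophenyl and 3-nitrophenyl give matching readings, and compound 2 alone stands apart. No measurement of any other property accompanies these numbers, so the reason for this split stays unknown.

The compounds shown leave open whether the low number of compound 2 needs both methoxy groups, or whether 3-methoxyphenyl or 4-methoxyphenyl alone would read like compound 2 rather than like compound 1 and compound 3. They also leave open where plain phenyl, or a ring bearing an amine such as 3-aminophenyl, would fall at this place.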